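Methoxy for vinyl on the core of compound 1

The source may report more compounds than this note shows. Statements on the series, on what has been measured and on what is new or still open speak of the compounds shown alone.

Compound 1, `C=Cc1cn2ncc(-c3ccnc(OC)c3)c2nc1NC`, is the reference point of this small set. In an assay on isolated protein for inhibition of activin receptor type-2A (Homo sapiens), read by 33P incorporation, with a stated time of 20 min, in the presence of a further agent that is not named here (a lower number here means a stronger inhibitor, a higher number a weaker inhibitor), compound 1 gives 190 nM, the lowest of the three numbers recorded. Compound 2, `COc1cn2ncc(-c3ccnc(OC(C)(C)C)c3)c2nc1-c1cnn(C)c1`, gives 800 nM in this assay, and compound 3, `c1cc2cc(c1)-c1cnn3ccc(nc13)NCCOCCO2`, gives 1300 nM; both gaps from compound 1 lie beyond the usual scatter. Compound 4, `CNc1nc2c(-c3ccnc(OC)c3)cnn2cc1OC`, has not yet been measured. It differs from compound 1 in one place: methoxy in place of vinyl on an aromatic carbon. For the measured compounds named here, no measured pair isolates this change, so its size cannot be read off directly. A small step is expected, if anything toward a higher number. The expected step is a 1.6-fold higher number from compound 1 to compound 4 (0.20 log units; within the scatter), within the scatter. Compound 4 is expected to give 300 nM in this assay, with a range of 100 nM to 900 nM.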

Compound 4, half-maximal inhibitory concentration: 310 nM
For compound 4 the middle estimate is 1.0-fold (0.01 log units) below the measured one; the measured number falls inside the stated range.
By their numbers in this assay, from the lowest: compounds 1 and 4 (each within the scatter of the next); then compounds 2 and 3 (each within the scatter of the next).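

This position, ortho to a methylamino group, now has a direct reading: methoxy in place of vinyl is a 1.6-fold higher number from compound 1 to compound 4 (0.21 log units; within the scatter) in this assay. The double bond outside the aromatic rings is therefore not required on this carbon to keep the number in this range, and a hydrogen-bond acceptor can enter here without a change that stands clear of the scatter. No measured evidence bears on why the two groups read alike.

Going by these compounds, how ethoxy, a primary amine or a nitrile would read on this carbon remains open. So does whether methoxy and vinyl still read alike when the methylamino group is replaced.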